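Turning One Stereocentre on a Growth Inhibitor

A few compounds are considered here, and "the series" means these few. Any claim that something is new, unique, unknown or untested is made for them only; others in the source may bear on it.

Measured in a functional assay on U-251 cells (Homo sapiens) for inhibition, read by sulforhodamine B assay, with a stated time of 48 h; on this read-out higher numbers stand for weaker inhibition of growth and lower numbers for stronger inhibition of growth:
- compound 1 `Cc1cn([C@H]2C[C@H](CC3=CC(=O)C(=O)C=C3)[C@@H](CO[Si](C)(C)C(C)(C)C)O2)c(=O)[nH]c1=O`: no result reported
- compound 2 `COc1ccc(C2([C@H]3C[C@H](n4cc(C)c(=O)[nH]c4=O)O[C@@H]3CO[Si](C)(C)C(C)(C)C)SCCCS2)cc1OC`: 3800 nM

Among the compounds with values here, compound 2 holds the only number so far, so it cannot yet be ranked against anything. Compound 3 `COc1ccc(C2([C@H]3C[C@@H](n4cc(C)c(=O)[nH]c4=O)O[C@@H]3CO[Si](C)(C)C(C)(C)C)SCCCS2)cc1OC` keeps every atom and bond of compound 2 and changes only in shape (the two compounds have the same atoms and bonds and differ only in configuration as drawn: 1 of 3 stereo elements differ; a stereocentre at a saturated ring carbon is drawn R in compound 2 and S in compound 3). Within the data shown here, no measured pair shows what such a change does, so a modest step toward weaker growth inhibition is expected in this assay, possibly none beyond the scatter. The estimate amounts to a small move (a 1.3-fold higher number from compound 2 to compound 3 (0.12 log units; within the scatter)). For compound 3 the expected value is about 5000 nM, with an estimated range (from 1800 nM to 15000 nM).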

Compound 3, concentration for 50% growth inhibition: 7410 nM
Compound 3: the middle estimate sits 1.5-fold (0.17 log units) below what was measured, and the stated range covers the measured number.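

Within the data shown here, this pair gives the first measured reading of what turning this saturated ring carbon from R to S does, with a single change behind it: the fact that compounds 2 and 3 differ only in the configuration as drawn In this assay, the step is a 2.0-fold higher number from compound 2 to compound 3 (0.29 log units; within the scatter), so this inversion separates the two compounds by no more than repeat measurements can. At this position and with these groups, the drawn configuration shows no clear effect on growth inhibition.

Still open, going by these compounds, is whether this stereocentre would matter with a free hydroxyl group in place of the silyl ether. The same question applies to an amine in place of the dimethoxyphenyl group.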